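A few compounds are considered here, and "the series" means these few. Any claim that something is new, unique, unknown or untested is made for them only; others in the source may bear on it.

The compounds here share one core and are compared in a functional assay on HT-29 cells (Homo sapiens) for inhibition; a higher number here means a weaker inhibitor, a lower number a stronger inhibitor. Compound 1 `CC(=O)Oc1ccc(/C=C/c2ccc3ccccc3c2)cc1` carries an acetyl on an oxygen on an aromatic ring, and compound 2 `COc1ccc(/C=C/c2ccc3ccccc3c2)cc1` carries a methyl in that place. In this assay compound 1 gives > 5000 nM, which is a limit of the assay and not a number. On these data alone, compound 2 gives > 5000 nM, which is likewise only a limit, so its true position remains unknown. Both measured compounds sit at the same limit: the limit of > 5000 nM in this assay, at which 2 of the 2 values shown sit. For the measured compounds named here, the only measured change is a step that the two limits leave unreadable from compound 1 to compound 2, and it therefore gives no size to build on.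

Compound 3 `FC(F)(F)Oc1ccc(/C=C/c2ccc3ccccc3c2)cc1` makes a different change at the same oxygen: trifluoromethyl in place of methyl on an oxygen on an aromatic ring, with trifluoromethyl in place of methyl. Going by the values given here, no measured step covers this exchange, so the data support no firm direction or size. The expectation rests on compound 2, with its limit of > 5000 nM, and a further report of only a limit would not be surprising. For compound 3 the expected value is 7000 nM, with an estimated range from 2000 nM to 20000 nM. The estimated step is a step that the limit leaves unreadable from compound 2 to compound 3.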

Compound 3, half-maximal inhibitory concentration: > 5000 nM
Compound 3 was reported as a limit (the forecaster's own chance of this, stated with the estimate: 65%); the middle value does not contradict the limit.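

Compound 3, like compound 1 and compound 2, stands only at a limit of this assay, so no step among these three compounds can be read: the limit of > 5000 nM in this assay, at which 3 of the 3 values shown sit.

The compounds shown leave open how strongly each of them inhibits, and whether acetyl, methyl or trifluoromethyl on this oxygen makes any difference.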